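Compound 1 and an Untested Dichlorophenyl Analogue

This account rests on a few compounds, and the source may have more. Where it says the series, first, only, none or still open, it means among the compounds named here.

Measured in a functional assay on B16-F10 cells (Homo sapiens) for cytotoxicity against B16-F10 (Mus musculus), read by MTT assay, with a stated time of 72 h; on this read-out higher numbers stand for an effect only at larger amounts of compound and lower numbers for an effect already at smaller amounts:
compound 1, `O=C1/C(=C\c2cccc(Br)c2)c2ccccc2N1c1c(Cl)cccc1Cl`, gives 8 ug/mL
compound 2, `Cc1ccc2nc(Cl)c(/C=C3\C(=O)N(c4c(Cl)cccc4Cl)c4ccccc43)cc2c1`, gives "not determined" (no result reported)
compound 3, `Cc1ccc2nc(Cl)c(/C=C3\C(=O)N(c4c(Cl)cccc4Cl)c4ccccc43)cc2c1C`, gives > 100 ug/mL, which is a limit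

Among the three measured compounds, compound 1 is the only one with a single number in this assay, where compound 1 gives 8 ug/mL. Compound 2 has no reported result in this assay. Compound 3 sits at the limit of > 100 ug/mL in this assay, at which 1 of the 3 values shown sits; this is a limit of the assay and not a number. Going by the values given here, no pair of measured compounds differs in just one place, so no measured step is available for comparison, and the behaviour of compound 1 cannot be set against a neighbour.

Compound 4, `O=C1/C(=C\c2c(Cl)cccc2Cl)c2ccccc2N1c1c(Cl)cccc1Cl`, has not been measured in this assay. It differs from compound 1 by 2,6-dichlorophenyl in place of 3-bromophenyl on a double-bonded chain carbon bound to a double-bonded ring carbon. Among the compounds with values here, with no measured step to lean on, the expected size of this step is modest: no change beyond the usual scatter, with a slight lean toward an effect only at somewhat larger amounts.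

Compound 4 is therefore estimated to give about 12 ug/mL in this assay, with a range from 4 ug/mL to 40 ug/mL. This estimate means a step of a 1.5-fold higher number from compound 1 to compound 4 (0.18 log units; within the scatter) that is expected to stay within the usual scatter of repeated measurements.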

Compound 4, concentration for half-maximal effect: > 100 ug/mL
Compound 4: only a limit was reported; the forecaster's own chance of this, stated with the estimate: 15%; middle value at least 8.3-fold (0.92 log units) away from the limit.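

Going by these compounds alone, the exchange of 3-bromophenyl for 2,6-dichlorophenyl on a double-bonded chain carbon bound to a double-bonded ring carbon gives the first measured step, an at least 12-fold higher number from compound 1 to compound 4 (1.09 log units; beyond the scatter), in this assay, and this step lies beyond the scatter. The group at this place is therefore not interchangeable on the core of compound 1, since this one change is enough to take a measurable value to a limit. For compound 4 the reading of > 100 ug/mL is a limit of the assay and not a number. With this result, a limit is no longer a single case in the series: the limit of > 100 ug/mL in this assay, at which 2 of the 4 values shown sit.

The step changes the kind of halogen, the number of halogens and their placing all at once, and the compounds shown do not separate these three changes. On these data alone, how 3-chlorophenyl, unsubstituted phenyl, or a phenyl carrying an amine or a carboxylic acid would read at this place in this assay remains open, as does whether any group here gives a lower number than compound 1 does.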